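The compounds below may be only part of what the source reports. "The series", "measured", "known", "first", "only" and "open" are said of these compounds alone.

Measured compounds:
Compound 1, `COc1c(O)cc(O)c2c(=O)cc(-c3cccc(F)c3)oc12`: "not determined" (no result reported) in a functional assay on A549 cells (Homo sapiens) for cytotoxicity, read by MTT assay, with a stated time of 48 h; on this read-out lower numbers stand for stronger inhibition and higher numbers for weaker inhibition.
Compound 2, `CCN(CC)CCCCOc1cc(O)c2c(=O)cc(-c3ccccc3)oc2c1OC`: 1000 nM in this assay.

Among the compounds with values here, compound 2 holds the only number reported in this assay; compound 1 shares the same core but carries no result, so nothing can be said of how its values relate to those of compound 2. Within the data shown here, no step between two measured compounds is available, and every expectation for a new compound therefore rests on compound 2 alone.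

Compound 3, `COc1c(OCc2cnoc2C)cc(O)c2c(=O)cc(-c3ccccc3)oc12`, departs from compound 2 by one change: 5-methyl-1,2-oxazol-4-yl in place of 3-(diethylamino)propyl on a saturated chain carbon bound to an oxygen on an aromatic ring. The group that leaves has no ring; the group that enters is a five-membered aromatic ring with two hetero atoms and two hydrogen-bond acceptors.

Among the measured compounds shown here, with no measured step to lean on, the account treats the change as open. The expected move from compound 2 to compound 3 is a 1.8-fold higher number from compound 2 to compound 3 (0.26 log units; within the scatter), that is, a shift toward weaker inhibition of a size not clearly beyond the scatter. Compound 3 is therefore estimated at 1800 nM in this assay, with a range from 400 nM to 8000 nM.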

Compound 3, half-maximal inhibitory concentration: > 100000 nM
Compound 3: no number, only a limit (the forecaster's own chance of this, stated with the estimate: 15%); at least 55-fold (1.74 log units) between middle value and limit.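

In this assay compound 3 carries no number but a limit of the assay: the limit of > 100000 nM in this assay, at which 1 of the 3 values shown sits.

Read against compound 2, placing 5-methyl-1,2-oxazol-4-yl in place of 3-(diethylamino)propyl on a saturated chain carbon bound to an oxygen on an aromatic ring gives an at least 100-fold higher number from compound 2 to compound 3 (2.00 log units; beyond the scatter), and this step is itself a bound, since one of its two ends is a limit. Within the data shown here, it is the first measured step available here, and it shows that the read-out at this place is far from indifferent to the group it carries: the five-membered aromatic ring on its short link does not keep the value of compound 2.

The change removes the amine and brings in the ring in one exchange, so the compounds shown do not tell whether the amine, the chain or the ring accounts for the step, and a plain butyl chain or a morpholine at the end of the butyl chain would be needed to separate them. Among these compounds, compound 1 has no result, so no step to it can be read, and the fluorine on its aromatic ring remains unassessed.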